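This account rests on a few compounds, and the source may have more. Where it says the series, first, only, none or still open, it means among the compounds named here.

Values in a functional assay on A549 cells (Homo sapiens) for inhibition, read by MTT assay, with a stated time of 48 h; on this read-out higher numbers stand for weaker inhibition and lower numbers for stronger inhibition:
- compound 1 `Nc1n[nH]c2cccc(-c3cccc(NC(=O)Nc4ccc(F)c(F)c4)c3)c12`: 3040 nM
- compound 2 `Nc1n[nH]c2cccc(-c3cccc(NC(=O)Nc4ccc(Cl)cc4Cl)c3)c12`: > 500000 nM (a limit)
- compound 3 `Nc1n[nH]c2cccc(-c3cccc(NC(=O)Nc4cc(C(F)(F)F)cc(C(F)(F)F)c4)c3)c12`: 1510 nM

Not yet measured: compound 4 `Nc1n[nH]c2cccc(-c3cccc(NC(=O)Nc4ccccc4F)c3)c12`.

Compound 2 gives no number, only a limit: the limit of > 500000 nM in this assay, at which 1 of the 3 values shown sits. Compound 4 has 2-fluorophenyl in place of 2,4-dichlorophenyl on an amide-type nitrogen. Among the measured compounds shown here, the one measured step that bears on this is an at least 160-fold higher number from compound 1 to compound 2 (2.21 log units; beyond the scatter), which is large and introduced the 2,4-dichlorophenyl group that is absent from compound 4. With that group gone, a similarly large move to a lower number is expected in this assay, though this rests on a single step. The expected change is an at least 83-fold lower number from compound 2 to compound 4 (1.92 log units; beyond the scatter). Compound 4 is estimated at 6000 nM, with an expected range of 1500 nM to 60000 nM.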

Compound 4, half-maximal inhibitory concentration: 1170 nM
The estimate for compound 4 lay 5.1-fold (0.71 log units) above the measured number; the measured number lies below the stated range.
By their numbers in this assay, from the lowest: compounds 4, 3 and 1 (each within the scatter of the next, the first and the last beyond it). At a limit, above all of these: compound 2.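

In this assay, replacing 2,4-dichlorophenyl with 2-fluorophenyl on the amide-type nitrogen gives an at least 420-fold lower number from compound 2 to compound 4 (2.63 log units; beyond the scatter), so the loss seen with compound 2 does not extend to every halogen-bearing phenyl at this place. Compound 2 gives only a limit, not a number: the limit of > 500000 nM in this assay, at which 1 of the 4 values shown sits.

Replacing 3,4-difluorophenyl with 2-fluorophenyl gives a 2.6-fold lower number from compound 1 to compound 4 (0.41 log units; beyond the scatter), so the fluorinated groups here keep low numbers, with compound 2 the exception.

From the compounds shown here alone, whether a phenyl carrying a single chlorine would keep a low number or follow compound 2 stays open, as does the effect of a methoxy group or an amine on this ring.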